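Swapping a Halogenated Ring for Benzothiophene in an Amide

This account rests on a few compounds, and the source may have more. Where it says the series, first, only, none or still open, it means among the compounds named here.

Among the measured compounds shown here, compound 2 `CC(=O)Nc1cccc2c(-c3cccc(NC(=O)c4cc(Cl)cc(C(F)(F)F)c4)c3)ccnc12` gives 6200 nM in a functional assay on A375P cells (Homo sapiens) for antiproliferative activity, read by MTT assay, with a stated time of 48 h (a lower number here means a stronger inhibitor, a higher number a weaker inhibitor), the highest of the two numbers measured so far; its nearest neighbour, compound 1 `CC(=O)Nc1cccc2c(-c3cccc(NC(=O)c4ccc(Cl)c(C(F)(F)F)c4)c3)ccnc12`, gives 2400 nM, and the step of a 2.6-fold higher number from compound 1 to compound 2 (0.41 log units; beyond the scatter) shows that even exchanging one chlorinated, trifluoromethyl-bearing ring for another shifts the result. Compound 3 `CC(=O)Nc1cccc2c(-c3cccc(NC(=O)c4cc5ccccc5s4)c3)ccnc12` carries a different change: 1-benzothiophen-2-yl in place of 3-chloro-5-(trifluoromethyl)phenyl on a carbonyl carbon. For the measured compounds named here, no measured step tests such an exchange, so the only guide is the modest size of a 2.6-fold higher number from compound 1 to compound 2 (0.41 log units; beyond the scatter). A shift of similar or somewhat larger size is expected, in an uncertain direction, giving a 1.8-fold lower number from compound 2 to compound 3 (0.25 log units; within the scatter). Compound 3 is therefore estimated at 3500 nM, within 800 nM to 15000 nM.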

Compound 3, half-maximal inhibitory concentration: 9100 nM
The estimate for compound 3 lay 2.6-fold (0.41 log units) below the measured number; the range from low to high includes it.
By their numbers in this assay, from the lowest: compound 1; then compounds 2 and 3 (each within the scatter of the next).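

On this carbonyl carbon, a ring system with no halogen, 1-benzothiophen-2-yl, can take the place of 3-chloro-5-(trifluoromethyl)phenyl with a step that stays within the scatter in this assay (a 1.5-fold higher number from compound 2 to compound 3 (0.17 log units; within the scatter)). Set against 4-chloro-3-(trifluoromethyl)phenyl, the same group gives a step beyond the scatter (a 3.8-fold higher number from compound 1 to compound 3 (0.58 log units; beyond the scatter)), so only compound 1 stands apart among these three. No measurement here explains either step. Still open, going by these compounds, is whether an amine or a carboxylic acid on the ring at this place would give a number lower than that of compound 1.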